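The source may hold more compounds than are shown below. What is called first, only, known or untested is meant among the compounds shown, and "the series" means these compounds.

Two members of the series have numbers in a functional assay on A549 cells (Homo sapiens) for cytotoxicity, read by WST assay, with a stated time of 24 h; on this read-out higher numbers stand for weaker inhibition and lower numbers for stronger inhibition. Compound 1 `COc1ccc2c(C(=O)/C(C#N)=C/c3c[nH]c4cc(F)ccc34)c[nH]c2c1` gives 2400 nM in this assay, and compound 2 `N#C/C(=C\c1c[nH]c2ccccc12)C(=O)c1c[nH]c2ccccc12` gives 16100 nM. On these two numbers compound 2 stands highest; compound 1 sits lower, a gap beyond the scatter. Compound 3 `N#C/C(=C\c1c[nH]c2cc(F)ccc12)C(=O)c1c[nH]c2ccccc12` is not yet measured. It differs from compound 2 by fluoro in place of hydrogen on an aromatic carbon. For the measured compounds named here, no measured pair isolates this change, so its size is open; a moderate drop in this assay is expected rather than none, since compound 1 gives 2400 nM and also carries fluoro. The step expected is a 2.3-fold lower number from compound 2 to compound 3 (0.36 log units; beyond the scatter). Compound 3 is estimated at 7000 nM, with a range of 3000 nM to 16000 nM.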

Compound 3, half-maximal inhibitory concentration: 17000 nM
Compound 3: middle estimate off by 2.4-fold (0.39 log units), on the low side; the measured number lies above the stated range.
By their numbers in this assay, from the lowest: compound 1; then compounds 2 and 3 (each within the scatter of the next).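

In this assay fluoro in place of hydrogen at this position, on an aromatic carbon of the six-membered ring, gives a 1.1-fold higher number from compound 2 to compound 3 (0.02 log units; within the scatter) and so leaves the number unchanged within the scatter. With fluoro held in place, hydrogen in place of methoxy gives a 7.1-fold higher number from compound 1 to compound 3 (0.85 log units; beyond the scatter) and accounts for the gap that fluoro alone does not. Nothing measured here explains either result.

On these data alone, whether methoxy lowers the number when hydrogen replaces fluoro remains open. So does whether chloro or an amine at the fluoro position would move it.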